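A few compounds are considered here, and "the series" means these few. Any claim that something is new, unique, unknown or untested is made for them only; others in the source may bear on it.

Among the compounds with values here, in a functional assay on A549 cells (Homo sapiens) for cytotoxicity, read by MTT assay, with a stated time of 72 h (on this read-out higher numbers stand for weaker inhibition and lower numbers for stronger inhibition), compound 2 (`Cn1ccc2c(Oc3ccc(NC(=O)c4cc5cccnc5n(-c5ccc(F)cc5)c4=O)cc3F)ncnc21`) gives 7320 nM and holds the only number so far. Within the data shown here, compound 1 (`Cn1ccc2c(Oc3ccc(NC(=O)c4cc5cccnc5n(-c5ccc(C(F)(F)F)c(Cl)c5)c4=O)cc3)ncnc21`) is reported as "not active" (no number reported) with no number, so no measured step is available as a guide. Compound 3 (`Cn1ccc2c(Oc3ccc(NC(=O)c4cc5cccnc5n(-c5ccc(C(F)(F)F)cc5Cl)c4=O)cc3F)ncnc21`) has 2-chloro-4-(trifluoromethyl)phenyl in place of 4-fluorophenyl on an aromatic nitrogen. Compound 1, which also has chloro and trifluoromethyl groups on that phenyl, gives "not active" (no number reported) and hints that inhibition will not improve. Only a small step toward weaker inhibition is therefore expected in this assay (a 1.2-fold higher number from compound 2 to compound 3 (0.09 log units; within the scatter)). Compound 3 is estimated at 9000 nM (expected range 2800 nM to 30000 nM).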

Compound 3, half-maximal inhibitory concentration: "not active" (no number reported)
Nothing numeric was reported for compound 3, and the estimate cannot be compared.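

Compound 3 gives "not active" (no number reported) in this assay and so offers no readable step from compound 2. Nothing shown here explains this result. On these data alone, how strongly compound 3 inhibits, and how the change of phenyl group alone affects the read-out, stays open.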